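The source may report more compounds than this note shows. Statements on the series, on what has been measured and on what is new or still open speak of the compounds shown alone.

Compound 1, `O=C(CCCc1ccccc1)Nc1nc2ccc(Cl)cc2c(=O)s1`, has "not determined" (no result reported) in an assay on CHO cells for displacement of a labelled ligand from adenosine receptor A1 (Homo sapiens), read by scintillation counting, with a stated time of 90 min; a lower number here means a stronger inhibitor, a higher number a weaker inhibitor.
Compound 2, `O=C(CCCc1ccccc1)Nc1nc2ccccc2c(=O)s1`, gives 2500 nM in this assay.
Compound 3, `O=C(CCc1ccccc1F)Nc1nc2ccccc2c(=O)s1`, has "not determined" (no result reported) in this assay.

Compound 2 therefore stands alone: it carries the only number shown in this assay, and the two other measured compounds contribute nothing to compare it with. Among the measured compounds shown here, no step between two measured compounds exists, so there is no reference for how large a change in this assay a single modification of the shared core of compound 2 produces.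

Compound 4, `Cc1ccc2nc(NC(=O)CCCc3ccccc3)sc(=O)c2c1`, is not yet measured. It differs from compound 2 in one place: methyl in place of hydrogen on an aromatic carbon. Without any measured pair to lean on, the expected step is small, in no clear direction, and most likely within the scatter of repeated measurements. Compound 4 is accordingly expected to give 2000 nM in this assay, with a range from 700 nM to 6000 nM. This estimate means a step of a 1.3-fold lower number from compound 2 to compound 4 (0.10 log units; within the scatter), which is expected to lie inside the usual scatter.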

Compound 4, inhibition constant: 1000 nM
Compound 4: the middle estimate sits 2.0-fold (0.30 log units) above what was measured; low and high end bracket the measured number.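

Methyl in place of hydrogen on this aromatic carbon gives a 2.5-fold lower number from compound 2 to compound 4 (0.40 log units; beyond the scatter) in this assay, the first measured step on the shared core of this series. The step is modest, but it shows that this position, meta to a fused ring and para to a fused ring, accepts a single added carbon and that the change moves the number toward a stronger inhibitor rather than a weaker one. Nothing measured here accounts for this shift.

From the compounds shown here alone, whether a larger group on this carbon, such as ethyl or methoxy, would lower the number further remains open, as does the effect of an amine or a carboxylic acid there. Going by these compounds, it is also open whether methyl on another carbon of this ring would give a step of similar size.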